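A few compounds are considered here, and "the series" means these few. Any claim that something is new, unique, unknown or untested is made for them only; others in the source may bear on it.

Compound 1 `CC(C)C(c1ncc[nH]1)c1ccc(-c2ccc3cccc(F)c3c2)[nH]c1=O` gives 33 nM
Compound 2 `CC(C)C(c1ccc(-c2ccc3cccc(F)c3c2)[nH]c1=O)N1CCNC1=O` gives 28 nM
Compound 3 `CC(C)C(/C=C1\CCNC1=O)c1ccc(-c2ccc3cccc(F)c3c2)[nH]c1=O` gives 8.7 nM

These values come from a functional assay on CHO cells for antagonist activity at prostaglandin E2 receptor EP3 subtype (Homo sapiens), read by cAMP accumulation; a higher number here means a weaker inhibitor, a lower number a stronger inhibitor. Compound 3 gives the lowest number of the three: its nearest neighbour is compound 2, with a 3.2-fold lower number from compound 2 to compound 3 (0.51 log units; beyond the scatter), and compound 1 sits furthest, with a 3.8-fold lower number from compound 1 to compound 3 (0.58 log units; beyond the scatter). Compound 4 `CC(C)C(CC(N)=O)c1ccc(-c2ccc3cccc(F)c3c2)[nH]c1=O` keeps the shared core and differs from compound 3 in one place: a group of 4 heavy atoms (2 carbon, 1 nitrogen, 1 oxygen; no ring) in place of a group of 7 heavy atoms (5 carbon, 1 nitrogen, 1 oxygen; one five-membered non-aromatic ring with 1 hetero atom), on a saturated chain carbon bound to an aromatic carbon and a saturated chain carbon. Both measured steps into compound 3 put the group that now leaves in place of a five-membered ring group, and both lowered the number by a modest amount. Among the measured compounds shown here, no measured step swaps a ring for an open chain, so the expectation rests on that gain being lost again. Compound 4 is therefore expected to give 30 nM, between 10 nM and 100 nM, a step of a 3.4-fold higher number from compound 3 to compound 4 (0.54 log units; beyond the scatter) in this assay.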

Compound 4, half-maximal inhibitory concentration: 53 nM
Estimate against measurement, compound 4: 1.8-fold (0.25 log units) below; low and high end bracket the measured number.
By their numbers in this assay, from the lowest: compound 3; then compounds 2, 1 and 4 (each within the scatter of the next).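

In this assay, replacing the ring-bearing group of compound 3 with open-chain carbamoylmethyl gives a 6.1-fold higher number from compound 3 to compound 4 (0.78 log units; beyond the scatter), so on this saturated chain carbon the open chain does not keep that group's advantage. Carbamoylmethyl does not stand apart from the other two groups, with a 1.9-fold higher number from compound 2 to compound 4 (0.28 log units; within the scatter) and a 1.6-fold higher number from compound 1 to compound 4 (0.21 log units; within the scatter), so only the group of compound 3 stands out so far. No measured evidence explains this result. Still open, as far as these compounds go, is whether that advantage rests on the ring or on its double bond, and how a carboxylic acid or a longer chain would read on this carbon.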